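Urea series: chloro in place of methoxy on the aryl ring

The compounds below may be only part of what the source reports. "The series", "measured", "known", "first", "only" and "open" are said of these compounds alone.

Measured compounds in an assay on microsomes from intestine for inhibition of acyl-CoA:cholesterol acyltransferase (Oryctolagus cuniculus); on this read-out higher numbers stand for weaker inhibition and lower numbers for stronger inhibition:
compound 1 `CC(C)c1cccc(C(C)C)c1NC(=O)NCC1(c2ccsc2)CCCC1`: 18 nM
compound 2 `O=C(NCC1(c2ccccc2)CCCCC1)Nc1ccccc1`: 2300 nM
compound 3 `COc1ccc(NC(=O)NCC2(c3ccccc3)CCCCC2)cc1`: 4900 nM

Compound 3 gives the highest number of the three in this assay; compound 2 sits nearest, and compound 1 lies far below both. Compound 4 `O=C(NCC1(c2ccccc2)CCCCC1)Nc1ccc(Cl)cc1` differs from compound 3 by chloro in place of methoxy on an aromatic carbon. Within the data shown here, no measured step covers this exchange directly. Among the measured compounds shown here, the one step that bears on it is the move from hydrogen to methoxy at the same place, a 2.1-fold higher number from compound 2 to compound 3 (0.33 log units; beyond the scatter), a modest weakening. Taking the methoxy away again could plausibly bring the number back toward that of compound 2; whether chloro does more than hydrogen at this place is unknown. For compound 4 a step of about a 2.5-fold lower number from compound 3 to compound 4 (0.39 log units; beyond the scatter) is expected. Compound 4 is therefore estimated at 2000 nM, with a range from 600 nM to 6000 nM.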

Compound 4, half-maximal inhibitory concentration: 2200 nM
Compound 4: middle estimate off by 1.1-fold (0.04 log units), on the low side; measured number inside the range.
By their numbers in this assay, from the lowest: compound 1; then compounds 4 and 2 (each within the scatter of the next); then compound 3.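

In this assay methoxy stands apart from hydrogen and chloro at this place (a 2.2-fold lower number from compound 3 to compound 4 (0.35 log units; beyond the scatter)), whereas chloro and hydrogen cannot be told apart (a 1.0-fold lower number from compound 2 to compound 4 (0.02 log units; within the scatter)). The 4-methoxyphenyl to 4-chlorophenyl exchange therefore removes the higher number seen with methoxy, and chloro offers no measurable gain over hydrogen on this core. Nothing on hand gives a reason for this.

Open, on these data alone, is whether an amine, a carboxylic acid or a longer chain on this aromatic carbon would separate from hydrogen. Also open, as far as these compounds go, is whether the chloro and methoxy exchange would read the same on the core of compound 1.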